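A Shorter Side Chain Under a Limit

The compounds below may be only part of what the source reports. "The series", "measured", "known", "first", "only" and "open" are said of these compounds alone.

In a functional assay on NCI-H460 cells (Homo sapiens) for cytotoxicity, read by MTT assay (on this read-out higher numbers stand for weaker inhibition and lower numbers for stronger inhibition), compound 1 (`Cc1c(O)cc(CCCCC(C)C)oc1=O`) gives > 200000 nM, which is a limit and not a number. Compound 2 (`CC(=O)C(C)CCCCc1cc(O)c(C)c(=O)o1`) gives > 200000 nM, which is also only a limit. The change to compound 3 (`Cc1c(O)cc(CCCC(C)C)oc1=O`) is isopropyl in place of 2-acetylpropyl (isopropyl in place of 2-acetylpropyl on a saturated chain carbon, three bonds along the chain from an aromatic carbon) on a saturated chain carbon, three bonds along the chain from an aromatic carbon. Among the compounds with values here, the one measured step, a step that the two limits leave unreadable from compound 1 to compound 2, offers no size to carry over. No step beyond the scatter is therefore expected in this assay in either direction, and the estimated step is a number no higher from compound 2 to compound 3 (the limit leaves the size open) overall. Compound 3 is estimated at 200000 nM (range 90000 nM to 400000 nM) in this expectation.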

Compound 3, half-maximal inhibitory concentration: > 200000 nM
Compound 3: only a limit was reported (the forecaster's own chance of this, stated with the estimate: 85%); the middle value sits exactly at the limit.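

No step can be read among compound 1, compound 2 and compound 3, because all three rest on one limit: the limit of > 200000 nM in this assay, at which 3 of the 3 values shown sit. The compounds shown leave open whether any side chain on the shared core gives a readable value in this assay at all.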